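Swapping the Aryl Ring on a Weak Sulfonamide

The source may hold more compounds than are shown below. What is called first, only, known or untested is meant among the compounds shown, and "the series" means these compounds.

Of the compounds shown here, two have been measured so far, both sharing a core that carries a sulfonamide. Compound 1 `O=S(=O)(Nc1ccc(-c2nc3cc(NS(=O)(=O)c4ccccc4)ccc3o2)cc1)c1ccccc1` gives 80000 nM in an assay on cells for inhibition of HSP60/HSP10 (Homo sapiens), with a stated time of 60 min (on this read-out lower numbers stand for stronger inhibition and higher numbers for weaker inhibition), which is weak inhibition. Compound 2 `O=S(=O)(Nc1ccc(-c2nc3ccccc3o2)cc1)c1ccccc1Cl` returned only a limit of this assay rather than a number, so compound 2 stands at > 100000 nM. This is the limit at which one of the two results sits (the limit of > 100000 nM in this assay, at which 1 of the 2 values shown sits), and it places compound 2 at the weak end of the values shown, without an exact figure.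

Compound 3 `COc1cccc(S(=O)(=O)Nc2ccc(-c3nc4ccccc4o3)cc2)c1` has not yet been measured. It differs from compound 2 in one place (3-methoxyphenyl in place of 2-chlorophenyl on a sulfonyl sulfur). Going by the values given here, no measured pair shows what this kind of change does, so the step from compound 2 to compound 3 is expected to stay within the scatter, with no clear direction. Compound 3 is therefore expected to give about 120000 nM in this assay, within 30000 nM to 500000 nM, and may again return only a limit a step that the limit leaves unreadable from compound 2 to compound 3.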

Compound 3, half-maximal inhibitory concentration: 80000 nM
Beside the measured number, compound 3's estimate is 1.5-fold (0.18 log units) above it; the range from low to high includes it.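

In this assay, putting 3-methoxyphenyl in place of 2-chlorophenyl on the sulfonyl sulfur gives an at least 1.2-fold lower number from compound 2 to compound 3 (0.09 log units; that floor lies within the scatter). Going by these compounds alone, this is the first measured pair to touch this position, and it shows that a swap of the aryl ring here can turn a limit into a readable number, though the floor of the step alone does not establish a real gain. The result for compound 2 is a limit and not a number, so the true size of this step cannot be read: the limit of > 100000 nM in this assay, at which 1 of the 3 values shown sits.

The two rings differ in both their group and its place, so the compounds shown cannot say whether the methoxy group or the loss of chlorine matters here. As far as these compounds go, it also remains open what an amine or a carboxylic acid on this aryl ring would give in this assay.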